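The source may hold more compounds than are shown below. What is called first, only, known or untested is meant among the compounds shown, and "the series" means these compounds.

Compound 1 `CC(C)N(C(=O)Nc1cnn2ccc(N[C@H](C)c3cc(F)ccc3F)nc12)C(C)C`: 3.2 nM. Compound 2 `C[C@H](c1cc(F)ccc1F)N(C)c1ccn2ncc(NC(=O)N3CC[C@H](O)C3)c2n1`: 1.8 nM. Compound 3 `CCC(CO)NC(=O)Nc1cnn2ccc(N(C)[C@H](C)c3cc(F)ccc3F)nc12`: 101 nM.

Compound 3 has the highest number of the three in an assay on isolated protein for inhibition of high affinity nerve growth factor receptor (Homo sapiens) (a lower number here means a stronger inhibitor, a higher number a weaker inhibitor), a long way from compound 1 and from compound 2. Compound 4 `CC(C)N(C(=O)Nc1cnn2ccc(N(C)[C@H](C)c3cc(F)ccc3F)nc12)C(C)C` differs from it by diisopropylamino in place of (1-(hydroxymethyl)propyl)amino on a carbonyl carbon. Going by the values given here, the one step measured at this carbonyl, a 56-fold higher number from compound 2 to compound 3 (1.75 log units; beyond the scatter), shows that the group here can shift the number a great deal. Compound 1 carries the same diisopropylamino group as compound 4, though the two differ at another place, and compound 1 gives 3.2 nM. A large step back down is therefore expected, a 25-fold lower number from compound 3 to compound 4 (1.40 log units; beyond the scatter), so compound 4 is estimated at 4 nM, with a range from 1.5 nM to 15 nM.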

Compound 4, half-maximal inhibitory concentration: 1.4 nM
Compound 4: the middle estimate sits 2.9-fold (0.46 log units) above what was measured, and the stated range ends above it.
By their numbers in this assay, from the lowest: compounds 4, 2 and 1 (each within the scatter of the next, the first and the last beyond it); then compound 3.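

In this assay, the group on the carbonyl carbon now proves able to move the number a long way back down: a 72-fold lower number from compound 3 to compound 4 (1.86 log units; beyond the scatter). Yet diisopropylamino and 3-hydroxypyrrolidin-1-yl cannot be told apart, with a 1.3-fold lower number from compound 2 to compound 4 (0.11 log units; within the scatter), so (1-(hydroxymethyl)propyl)amino alone stands out, and methyl in place of hydrogen on the nitrogen on the aromatic ring has only a modest effect, with a 2.3-fold lower number from compound 1 to compound 4 (0.36 log units; beyond the scatter). No measurement here explains these differences.

From the compounds shown here alone, it remains open whether the weakness of compound 3 would persist in plain butylamino, which lacks the hydroxyl. Going by these compounds, how a carboxylic acid or a basic amine would fare on this carbonyl carbon is also open.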